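The source may hold more compounds than are shown below. What is called first, only, known or untested is meant among the compounds shown, and "the series" means these compounds.

Working notes on a series built on a shared core. Compound 1 `Cc1ccccc1CN1CCc2c(sc(NC(=O)c3ccccc3Cl)c2C(N)=O)C1` gives in a functional assay on HeLa cells (Homo sapiens) for antiproliferative activity, with a stated time of 24 h (a higher number here means a weaker inhibitor, a lower number a stronger inhibitor), only a limit, > 50000 nM. Compound 2 `Cc1ccc(C(=O)Nc2sc3c(c2C(N)=O)CCN(Cc2ccc(Cl)cc2Cl)C3)cc1` also returns only a limit in this assay, > 50000 nM. Compound 3 `NC(=O)c1c(NC(=O)c2ccccc2Cl)sc2c1CCN(C(=S)Nc1cccc3ccccc13)C2` reaches a measured value in this assay of 30800 nM. Compound 1 thus stands at the limit of > 50000 nM in this assay, at which 2 of the 3 values shown sit, with no number to fix its potency. Compound 4 `NC(=O)c1c(NC(=O)c2ccccc2Cl)sc2c1CCN(C(=O)Nc1c(Cl)cccc1Cl)C2` carries the change ((2,6-dichlorophenyl)carbamoyl in place of 2-methylbenzyl on an amine nitrogen in a ring). Within the data shown here, no step between measured compounds exists here, so the move is uncertain; only a modest gain, if any, is expected, because compound 3 gives 30800 nM. The expected step of an at least 1.4-fold lower number from compound 1 to compound 4 (0.15 log units; that floor lies within the scatter) is small. For compound 4 the estimated value in this assay is 35000 nM, ranging from 12000 nM to 80000 nM.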

Compound 4, half-maximal inhibitory concentration: 27200 nM
For compound 4 the middle estimate is 1.3-fold (0.11 log units) above the measured one; the measured number falls inside the stated range.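

On the amine nitrogen in a ring, (2,6-dichlorophenyl)carbamoyl in place of 2-methylbenzyl gives in this assay an at least 1.8-fold lower number from compound 1 to compound 4 (0.26 log units; that floor lies within the scatter). As far as these compounds go, compound 1 stands at a limit, so this step is only a floor and its true size remains unknown. With the same 2-chlorobenzoyl side, compound 3 gives 30800 nM and compound 4 gives 27200 nM, so this nitrogen now has two measured values, neither of them strong.

The compounds shown do not separate the contribution of the carbonyl link from that of the dichlorophenyl ring. From the compounds shown here alone, whether an acetyl group or a carboxylic acid at this nitrogen would give a lower number remains open.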